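The source may hold more compounds than are shown below. What is called first, only, known or untested is meant among the compounds shown, and "the series" means these compounds.

Working notes on the thienopyrimidine-free description: two compounds of the shared core carry a measurement, one more awaits it.

Compound 1 `C=CS(=O)(=O)N1CCN(c2ncnc3sc(-c4c(C)noc4C)cc23)CC1` and compound 2 `CCS(=O)(=O)N1CCN(c2ncnc3sc(-c4ccc(N5CCN(C)CC5)cc4)cc23)CC1` were tested in a functional assay on MDA-MB-231 cells (Homo sapiens) for antiproliferative activity, read by MTT assay, with a stated time of 48 h; a higher number here means a weaker inhibitor, a lower number a stronger inhibitor. In this assay compound 1 gives 28200 nM, and compound 2 gives 7330 nM. Compound 2 holds the lower of the two numbers, and the gap up to compound 1 lies beyond the usual scatter, so compound 2 is the stronger of the pair on what is shown.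

Compound 3 `CN1CCN(c2ccc(-c3cc4c(N5CCN(C(=O)Nc6ccc(F)cc6F)CC5)ncnc4s3)cc2)CC1` has not been measured. It differs from compound 2 in one place: (2,4-difluorophenyl)carbamoyl in place of ethylsulfonyl on an amine nitrogen in a ring. For the measured compounds named here, no pair of measured compounds shows such a swap, so the size of the step from compound 2 to compound 3 cannot be read off; the expectation is a modest gain in potency, a step of a 2.4-fold lower number from compound 2 to compound 3 (0.39 log units; beyond the scatter), with a range wide enough to admit no change beyond the scatter. Compound 3 is thus expected to give about 3000 nM in this assay, between 800 nM and 12000 nM.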

Compound 3, half-maximal inhibitory concentration: 11400 nM
Compound 3: middle estimate off by 3.8-fold (0.58 log units), on the low side; the range from low to high includes it.
By their numbers in this assay, from the lowest: compounds 2 and 3 (each within the scatter of the next); then compound 1.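

At the amine nitrogen in the six-membered non-aromatic ring, this assay does not separate the two groups: (2,4-difluorophenyl)carbamoyl in place of ethylsulfonyl gives a 1.6-fold higher number from compound 2 to compound 3 (0.19 log units; within the scatter). This single pair shows that a sulfonyl group on this nitrogen is not needed to keep the number at this level, and that an added aromatic ring and hydrogen-bond donor in the entering group leave it within the scatter. No supporting measurement bears on why the two groups read alike.

Open, as far as these compounds go, is whether a free amine, an acetyl group or a longer alkyl chain on this nitrogen would move the number beyond the scatter. Also open, from the compounds shown here alone, is whether the same exchange reads alike when the rest of the molecule is that of compound 1.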